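The compounds below may be only part of what the source reports. "The series", "measured", "known", "first", "only" and "open" are said of these compounds alone.

In a functional assay on MGC-803 cells (Homo sapiens) for cytotoxicity, read by MTT assay, with a stated time of 72 h (a higher number here means a weaker inhibitor, a lower number a stronger inhibitor), compound 1 `CC(C)=C1C(=O)N(c2ccc(Cl)cc2)N(c2ccc(Cl)cc2)C1=O` gives 39000 nM. Going by the values given here, compound 2 `COc1cccc(C=C2C(=O)N(c3ccc(Cl)cc3)N(c3ccc(Cl)cc3)C2=O)c1O` gives 24300 nM in this assay, the lower of the two numbers so far, although the gap to compound 1 lies within the scatter, so the two are not ranked against each other. Compound 3 `O=C1C(=Cc2ccco2)C(=O)N(c2ccc(Cl)cc2)N1c1ccc(Cl)cc1` is not yet measured. It differs from compound 2 by furan-2-yl in place of 2-hydroxy-3-methoxyphenyl on a double-bonded chain carbon bound to a double-bonded ring carbon. Among the compounds with values here, no measured pair of compounds shows what this change does in this assay. The step is expected to stay within the scatter, with no direction assigned: a 1.2-fold higher number from compound 2 to compound 3 (0.09 log units; within the scatter). Compound 3 is therefore estimated at 30000 nM, with a range from 12000 nM to 75000 nM.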

Compound 3, half-maximal inhibitory concentration: 12800 nM
Compound 3: middle estimate off by 2.3-fold (0.37 log units), on the high side; the range from low to high includes it.
By their numbers in this assay, from the lowest: compounds 3, 2 and 1 (each within the scatter of the next, the first and the last beyond it).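

Putting furan-2-yl in place of 2-hydroxy-3-methoxyphenyl on a double-bonded chain carbon bound to a double-bonded ring carbon gives a 1.9-fold lower number from compound 2 to compound 3 (0.28 log units; within the scatter) in this assay. This position therefore accepts a five-membered aromatic ring with one hetero atom and no hydrogen-bond donor, with no change beyond the scatter. No accompanying measurement bears on this step.

Still open, going by these compounds, is whether any group at this place moves the number beyond the scatter. A phenyl ring carrying an amine or a carboxylic acid would test this.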